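The source may hold more compounds than are shown below. What is called first, only, known or untested is meant among the compounds shown, and "the series" means these compounds.

Measured compounds:
compound 1 `CCOC(=O)COc1cc(=O)oc2cc(OCc3cccc(Cl)c3)ccc12`; in an assay on isolated protein (strain Sprague-Dawley) for inhibition of Amine oxidase [flavin-containing] B (Rattus norvegicus), read by spectrophotometry, with a stated time of 5 min (on this read-out lower numbers stand for stronger inhibition and higher numbers for weaker inhibition), compound 1 gives 1820 nM.
compound 2 `CNc1cc(=O)oc2cc(OCc3cccc(Cl)c3)ccc12`; in this assay compound 2 gives 8.71 nM.

Compound 2 stands lowest of the two numbers shown. Among the compounds with values here, the only measured step is a 210-fold lower number from compound 1 to compound 2 (2.32 log units; beyond the scatter), and it concerns a different position. Compound 3 `O=c1cc(Nc2ccccc2)c2ccc(OCc3cccc(Cl)c3)cc2o1` carries phenyl in place of methyl on a nitrogen on an aromatic ring. Within the data shown here, no measured step bears on this change, so its direction is unknown; the step in this assay is therefore expected to be modest, the estimate being a 3.4-fold higher number from compound 2 to compound 3 (0.54 log units; beyond the scatter). Compound 3 is estimated at 30 nM, with a range of 3 nM to 300 nM.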

Compound 3, half-maximal inhibitory concentration: 9770 nM
The estimate for compound 3 lay 330-fold (2.51 log units) below the measured number; measured number above the stated range.
By their numbers in this assay, from the lowest: compound 2; then compound 1; then compound 3.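

Phenyl in place of methyl on a nitrogen on an aromatic ring gives a 1100-fold higher number from compound 2 to compound 3 (3.05 log units; beyond the scatter) in this assay and shows that the group on this nitrogen governs the number. Anilino in place of (ethoxycarbonyl)methoxy gives a 5.4-fold higher number from compound 1 to compound 3 (0.73 log units; beyond the scatter) on the same carbon, so a nitrogen at this place does not by itself bring a low number. Nothing at hand accounts for the change. The compounds shown leave open where between methyl and phenyl the number turns. An ethyl chain, a cyclopropyl ring or the unsubstituted amine on this nitrogen would narrow that.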